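The compounds below may be only part of what the source reports. "The series", "measured", "known", "first", "only" and "open" are said of these compounds alone.

Of the compounds shown here, three have been tested in a functional assay on A2780 cells (Homo sapiens) for inhibition; on this read-out lower numbers stand for stronger inhibition and higher numbers for weaker inhibition.

Compound 1 `Cc1cc(-c2ccc(Cl)cc2)cc(=O)o1` gives only a limit in this assay, > 50000 nM.
Compound 2 `Cc1ccc(-c2cc(C)oc(=O)c2)cc1` likewise gives only a limit in this assay, > 50000 nM.
Compound 3 `CCc1cc(C)oc(=O)c1` also gives only a limit in this assay, > 50000 nM.

Compound 3 therefore stands at the assay limit, not at a number, as do the other two; the limit of > 50000 nM in this assay, at which 3 of the 3 values shown sit, describes this. Among the compounds with values here, the one step between measured compounds that differ in a single place, a step that the two limits leave unreadable from compound 1 to compound 2, cannot be read because both ends sit at that limit. Compound 4 `CCCCc1cc(C)oc(=O)c1` differs from compound 3 by ethyl in place of hydrogen on a saturated chain carbon, two bonds along the chain from an aromatic carbon. Within the data shown here, no measured step bears on this chain extension, and the measured values give no foothold for reading a direction or size. Compound 4 is therefore expected to remain at or near the limit, an estimated step that the limit leaves unreadable from compound 3 to compound 4, with an estimate of 60000 nM and a range from 15000 nM to 250000 nM.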

Compound 4, half-maximal inhibitory concentration: > 50000 nM
Compound 4: a limit, no number; the forecaster's own chance of this, stated with the estimate: 85%; the middle value is on the limit's open side.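

No new step can be read, since compound 3 and compound 4 both sit at a limit in this assay: the limit of > 50000 nM in this assay, at which 4 of the 4 values shown sit.

The compounds shown leave open whether any change to the shared core gives a measurable value in this assay.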